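Alpha-Methyl Branching on the Acid Chain of Compound 1

This account rests on a few compounds, and the source may have more. Where it says the series, first, only, none or still open, it means among the compounds named here.

Compound 1 `Cc1nc(-c2ccc(C(F)(F)F)cc2)sc1CNc1ccc(CC(=O)O)cc1` is one of two compounds tested in a functional assay on CHO cells for agonist activity at Free fatty acid receptor 1 (Homo sapiens), read by a luciferase reporter; on this read-out lower numbers stand for smaller maximal responses and higher numbers for larger maximal responses. In this assay compound 1 gives 18%, the lower of the two numbers. The other compound, compound 2 `O=C(O)COc1ccc(NCc2cccc(Oc3ccccc3)c2)cc1`, in this assay gives 84%, a number far above that of compound 1 and well beyond the usual scatter; the two compounds differ in several places at once, so their values can only be set side by side, not traced to one change.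

Compound 3 `Cc1nc(-c2ccc(C(F)(F)F)cc2)sc1CNc1ccc(CC(C)C(=O)O)cc1` shares the core of compound 1 and differs from it in a single spot: 1-carboxyethyl in place of carboxy on a saturated chain carbon bound to an aromatic carbon. Within the data shown here, no pair of measured compounds shows this particular change, so the direction of the step can only be estimated from compound 1 alone. The account here expects the branched acid to raise the maximal response, and estimates the step in this assay as a number 22 percentage points higher from compound 1 to compound 3 (beyond the scatter), a change beyond the scatter but not of the size seen between compound 1 and compound 2. In this assay compound 3 is therefore expected to give about 40%, within a range from 15% to 75%.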

Compound 3, largest response reached (reported as percent of maximum), in percent of the reference or control that the assay uses: 100%
For compound 3 the middle estimate is 60 percentage points below the measured one, and the stated range ends below it.
By their numbers in this assay, from the lowest: compound 1; then compound 2; then compound 3.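

Among these compounds, the swap of carboxy for 1-carboxyethyl, on a saturated chain carbon bound to an aromatic carbon, is the first change in this set that can be read on its own: in this assay it gives a number 82 percentage points higher from compound 1 to compound 3 (beyond the scatter) with the rest of the core of compound 1 left as it was. This shows that the maximal response is highly sensitive to this one place on the acid chain, which the side-by-side values of compound 1 and compound 2 could not show, since those two compounds differ in several places at once. The groups that leave and enter carry the same count of hydrogen-bond donors and acceptors and no net charge, yet nothing shown here explains why the response moves so far.

From the compounds shown here alone, it remains open whether 1-carboxypropyl, with its longer chain, or a cyclopropane ring bearing the carboxylic acid at this place would keep the response seen for compound 3. Going by these compounds, it is also open whether the same change would have a comparable effect on the core of compound 2.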